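This account rests on a few compounds, and the source may have more. Where it says the series, first, only, none or still open, it means among the compounds named here.

Three compounds measured in a functional assay on COLO 205 cells (Homo sapiens) for cytotoxicity, read by MTT assay, with a stated time of 72 h (a lower number here means a stronger inhibitor, a higher number a weaker inhibitor), set the stage. Compound 1 `COc1cccc(/C=C/C(=O)Nc2cc(OC)c(OC)c(OC)c2)c1` gives 4200 nM. Compound 2 `COc1ccc(C(=O)c2cc(OC)c(OC)c(OC)c2)cc1NC(=O)/C=C/c1ccc(F)cc1` gives 3400 nM, and compound 3 `COc1ccc(C(=O)c2cc(OC)c(OC)c(OC)c2)cc1NC(=O)/C=C/c1ccc(C(F)(F)F)cc1` gives 2600 nM. Compound 2 sits in the middle of these three numbers, yet neither gap around it reaches beyond the usual scatter, so the three compounds cannot be told apart on potency with confidence. For the measured compounds named here, the one single-point step recorded among them, from compound 2 to compound 3, read a 1.3-fold lower number from compound 2 to compound 3 (0.12 log units; within the scatter), a change on the far ring that left the number essentially where it was.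

Compound 4 `COc1ccc(C(=O)c2cc(OC)c(OC)c(OC)c2)cc1NC(=O)/C=C/c1ccc(N)cc1` is the next member, not yet measured. It differs from compound 2 by amino in place of fluoro on an aromatic carbon. Going by the values given here, no measured pair shows this exact exchange, so the only guidance is the step from compound 2 to compound 3, which touched the same position on the same ring and stayed within the scatter. On that basis the exchange is expected to move the number little, if at all. Compound 4 is therefore estimated at 3000 nM in this assay, within a range from 1000 nM to 9000 nM, a step from compound 2 of a 1.1-fold lower number from compound 2 to compound 4 (0.05 log units; within the scatter), expected to stay inside the scatter.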

Compound 4, half-maximal inhibitory concentration: 10300 nM
For compound 4 the middle estimate is 3.4-fold (0.54 log units) below the measured one; measured number above the stated range.
By their numbers in this assay, from the lowest: compounds 3, 2 and 1 (each within the scatter of the next); then compound 4.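

This position is not indifferent to what it carries. In this assay, amino in place of fluoro gives a 3.0-fold higher number from compound 2 to compound 4 (0.48 log units; beyond the scatter), and amino in place of trifluoromethyl gives a 4.0-fold higher number from compound 3 to compound 4 (0.60 log units; beyond the scatter), both modest but beyond the scatter. The earlier step, a 1.3-fold lower number from compound 2 to compound 3 (0.12 log units; within the scatter), had made the position look tolerant, but that view rested on fluoro and trifluoromethyl alone, and amino now shifts the number towards a weaker inhibitor, while no measurement shown here explains why.

The compounds shown leave open whether this shift belongs to amino alone or would also appear with a hydroxyl group, a dimethylamino group or an acetamide on the same aromatic carbon, which would test whether the hydrogen-bond donor that amino brings and fluoro lacks goes along with the weaker number. For the compounds shown here, with no compound here carrying plain hydrogen at that carbon as a reference, it also remains open how far fluoro, trifluoromethyl or amino each moves the number on its own.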